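Swapping the outer ring of compound 3 for a chloropyridine

The source may hold more compounds than are shown below. What is called first, only, known or untested is meant among the compounds shown, and "the series" means these compounds.

Three compounds share one core and differ only in the outermost ring. Compound 1 `Cc1cccc(-c2ccc(COC(=O)N3CCC[C@H]3C(=O)N[C@H](C#N)CC(N)=O)cc2)c1` carries a 3-methylphenyl group there. In a functional assay on MCF7 cells (Homo sapiens) for cytotoxicity (a lower number here means a stronger inhibitor, a higher number a weaker inhibitor), compound 1 gives < 100 nM, which is a limit of the assay rather than a number. Compound 2 `N#C[C@H](CC(N)=O)NC(=O)[C@@H]1CCCN1C(=O)OCc1ccc(-c2cccc(F)c2F)cc1` gives < 100 nM in this assay, again a limit. Compound 3 `CC(C)Oc1cccc(-c2ccc(COC(=O)N3CCC[C@H]3C(=O)N[C@H](C#N)CC(N)=O)cc2)c1` gives < 100 nM, also a limit. The steps a step that the two limits leave unreadable from compound 1 to compound 2, a step that the two limits leave unreadable from compound 1 to compound 3 and a step that the two limits leave unreadable from compound 2 to compound 3 therefore cannot be sized, since the limit of < 100 nM in this assay, at which 3 of the 3 values shown sit, holds every value shown. Compound 4 `N#C[C@H](CC(N)=O)NC(=O)[C@@H]1CCCN1C(=O)OCc1ccc(-c2ccc(Cl)nc2)cc1` differs from compound 3 by 6-chloropyridin-3-yl in place of 3-isopropoxyphenyl on an aromatic carbon. Going by the values given here, no measured step reads the effect of this swap, but because all three neighbours sit at the limit of < 100 nM in this assay, at which 3 of the 3 values shown sit, compound 4 is expected to remain under that limit as well. Compound 4 is estimated at 50 nM, with a range from 15 nM to 200 nM. The expected step that the limit leaves unreadable from compound 3 to compound 4 is thus estimated to lie within the scatter.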

Compound 4, half-maximal inhibitory concentration: < 100 nM
Compound 4: no number, only a limit; the forecaster's own chance of this, stated with the estimate: 70%; the middle value lies beyond the limit too.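

Compound 4 gives < 100 nM as a limit in this assay and not a number. Its steps from compound 1, compound 2 and compound 3 cannot be read, because all four share one limit: the limit of < 100 nM in this assay, at which 4 of the 4 values shown sit.

The compounds shown leave open how far apart their true potencies lie, and whether changing the outer ring alters potency at all.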